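This account rests on a few compounds, and the source may have more. Where it says the series, first, only, none or still open, it means among the compounds named here.

Among the measured compounds shown here, in a functional assay on MDA-MB-231 cells (Homo sapiens) for inhibition, read by MTT assay, with a stated time of 72 h (a higher number here means a weaker inhibitor, a lower number a stronger inhibitor), compound 2, `C=CC(=O)Nc1cccc(NC(=O)CSc2nc(Nc3cccc(Cl)c3)c3ccccc3n2)c1`, gives 16300 nM, the higher of the two numbers measured so far. Its nearest neighbour is compound 1, `O=C(CSc1nc(Nc2ccccc2)c2ccccc2n1)Nc1ccc(Br)cc1`, which in this assay gives 11500 nM; the gap between the two values lies within the scatter, so the numbers show no difference in strength between compound 1 and compound 2.

Compound 3, `C=CC(=O)Nc1cccc(NC(=O)CSc2nc(Nc3ccc(Br)cc3)c3ccccc3n2)c1`, has not yet been measured. It differs from compound 2 in one place: 4-bromophenyl in place of 3-chlorophenyl on a nitrogen on an aromatic ring. The same group that enters here is already present in compound 1, which sits within the scatter of compound 2.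

Because compound 1 gives 11500 nM with the 4-bromophenyl group already in place, the author expects no step beyond the scatter from compound 2 to compound 3 in this assay, a 1.3-fold lower number from compound 2 to compound 3 (0.10 log units; within the scatter). The estimate for compound 3 is therefore 13000 nM, with a range from 5000 nM to 35000 nM.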

Compound 3, half-maximal inhibitory concentration: 17300 nM
Compound 3: the middle estimate sits 1.3-fold (0.12 log units) below what was measured; low and high end bracket the measured number.
By their numbers in this assay, from the lowest: compounds 1, 2 and 3 (each within the scatter of the next).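

In this assay, 4-bromophenyl in place of 3-chlorophenyl on a nitrogen on an aromatic ring gives a 1.1-fold higher number from compound 2 to compound 3 (0.03 log units; within the scatter), so the numbers do not tell compound 2 and compound 3 apart. Among the compounds shown here, this is the first direct reading at this place, which compound 1, differing from compound 2 in more than one place, could not give. The step alters both the halogen and where it sits on the phenyl ring, and a single step cannot separate the two.

The compounds shown leave open whether a group of another kind at this place, such as an aminophenyl group, a carboxylic acid or a longer alkyl chain, would read differently in this assay. No evidence available here speaks to why compound 2 and compound 3 read alike.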